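A few compounds are considered here, and "the series" means these few. Any claim that something is new, unique, unknown or untested is made for them only; others in the source may bear on it.

In a functional assay on PC-3 cells (Homo sapiens) for cytotoxicity, read by sulforhodamine B assay, with a stated time of 72 h (a higher number here means a weaker inhibitor of growth, a lower number a stronger inhibitor of growth), compound 1 `CCCC(=O)N1c2ccccc2CCC1C(=O)Nc1ccccc1C(F)(F)F` gives only a limit, > 70000 nM. Compound 2 `CC(=O)N1c2ccccc2CCC1C(=O)Nc1ccccc1C(F)(F)F` gives in this assay likewise only a limit, > 80000 nM. The step that the two limits leave unreadable from compound 1 to compound 2 cannot be read, because both values sit at the limits the limit of > 70000 nM in this assay, at which 1 of the 2 values shown sits, and (the limit of > 80000 nM in this assay, at which 1 of the 2 values shown sits). Compound 3 `O=C(Nc1ccccc1C(F)(F)F)C1CCc2ccccc2N1C(=O)c1ccccc1Cl` differs from compound 2 by 2-chlorophenyl in place of methyl on a carbonyl carbon. No readable measured step bears on this change, so neither size nor direction of the step in this assay can be drawn from the data. Compound 3 is estimated at 50000 nM, with a range from 12000 nM to 150000 nM. The expected step is thus an at least 1.6-fold lower number from compound 2 to compound 3 (0.20 log units; that floor lies within the scatter).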

Compound 3, concentration for 50% growth inhibition: 5140 nM
Compound 3: middle estimate off by 9.7-fold (0.99 log units), on the high side; the measured number lies below the stated range.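

In this assay, going by these compounds alone, 2-chlorophenyl on the carbonyl carbon gives the first step at this position that can be read (an at least 15-fold lower number from compound 2 to compound 3 (1.19 log units; beyond the scatter)), and the comparison with propyl in that place points the same way (an at least 13-fold lower number from compound 1 to compound 3 (1.13 log units; beyond the scatter)). Of the three groups shown there, only 2-chlorophenyl gives a number rather than a limit. The first step is only a floor, because compound 2 gives just a limit: the limit of > 80000 nM in this assay, at which 1 of the 3 values shown sits. The compounds shown leave open whether the chlorine or the ring accounts for the step, which a plain phenyl or a cyclohexyl on the same carbonyl carbon would help to separate.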